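From 3-fluorophenyl to pyrimidin-2-yl: one open question

The source may report more compounds than this note shows. Statements on the series, on what has been measured and on what is new or still open speak of the compounds shown alone.

Measured in a functional assay on COR-L23 cells (Homo sapiens) for antiproliferative activity, read by CellTiter-Glo, with a stated time of 72 h; a higher number here means a weaker inhibitor, a lower number a stronger inhibitor:
- compound 1 `C[C@H](NC(=O)c1ncccn1)c1ccc(NC(=O)N2CC(c3cccnc3)C2)cc1`: 130 nM
- compound 2 `C[C@H](NC(=O)c1cccc(F)c1)c1ccc(NC(=O)N2CC(c3ccc(N)nc3)C2)cc1`: 27 nM

Compound 2, at 27 nM, holds the lower of the two numbers, and its gap to compound 1 lies beyond the scatter of repeat measurements. Compound 3 `C[C@H](NC(=O)c1ncccn1)c1ccc(NC(=O)N2CC(c3ccc(N)nc3)C2)cc1` keeps the rest of compound 2 and changes one group: pyrimidin-2-yl in place of 3-fluorophenyl on a carbonyl carbon. In words, pyrimidin-2-yl stands in place of 3-fluorophenyl on a carbonyl carbon. Going by the values given here, no pair of measured compounds isolates this change, so its size cannot be read directly. Compound 1 carries the same pyrimidin-2-yl and gives 130 nM, but it also differs from compound 3 elsewhere. A small move towards a higher number in this assay is therefore expected, possibly no larger than the scatter. The expected change is a 1.9-fold higher number from compound 2 to compound 3 (0.27 log units; within the scatter). For compound 3 the estimate is 50 nM, with an expected range of 15 nM to 150 nM.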

Compound 3, half-maximal inhibitory concentration: 160 nM
Beside the measured number, compound 3's estimate is 3.2-fold (0.51 log units) below it, and the stated range ends below it.
By their numbers in this assay, from the lowest: compound 2; then compounds 1 and 3 (each within the scatter of the next).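

Going by these compounds alone, with only one group changed, pyrimidin-2-yl in place of 3-fluorophenyl on a carbonyl carbon gives a 5.9-fold higher number from compound 2 to compound 3 (0.77 log units; beyond the scatter) in this assay and so shows that the number at this position depends on which ring the carbonyl carries. With pyrimidin-2-yl held fixed, amino in place of hydrogen on an aromatic carbon gives a 1.2-fold higher number from compound 1 to compound 3 (0.09 log units; within the scatter) and so leaves no difference that stands clear of the scatter for this pair. The data shown offer no measured explanation for the size of either step.

Open, on these data alone, is whether a ring with a single nitrogen, such as pyridin-2-yl, would give a number closer to that of compound 2 or that of compound 3. Also open, as far as these compounds go, is whether the amino group would have the same small effect with 3-fluorophenyl on the carbonyl carbon.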